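Thiourea-linked pyridyl in place of the dichlorobenzyl

The source may report more compounds than this note shows. Statements on the series, on what has been measured and on what is new or still open speak of the compounds shown alone.

Measured compounds:
compound 1 `NC(=O)c1c(NC(=O)c2ccccc2Cl)sc2c1CCN(Cc1cc(Cl)cc(Cl)c1)C2` — 15800 nM
compound 2 `NC(=O)c1c(NC(=O)c2ccc(C(F)(F)F)cc2)sc2c1CCN(Cc1ccc(Cl)cc1)C2` — > 50000 nM
compound 3 `NC(=O)c1c(NC(=O)c2ccc(C(F)(F)F)cc2)sc2c1CCN(Cc1c(Cl)cccc1Cl)C2` — 10600 nM

In a functional assay on HL-60 cells (Homo sapiens) for antiproliferative activity, with a stated time of 24 h (a lower number here means a stronger inhibitor, a higher number a weaker inhibitor), compound 1 gives 15800 nM. Compound 3 gives 10600 nM. The value of compound 2 is a limit of the assay, not a number. Compound 1 thus holds the higher of the two numbers shown, with compound 3 within the scatter of it, so the two cannot be ordered. One of the three values sits at the limit of > 50000 nM in this assay, at which 1 of the 3 values shown sits.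

Among the measured compounds shown here, the only single-point step among the measured compounds is an at least 4.7-fold lower number from compound 2 to compound 3 (0.67 log units; beyond the scatter), which moves chlorines about on a benzyl group while keeping the benzyl itself.

Compound 4 `NC(=O)c1c(NC(=O)c2ccccc2Cl)sc2c1CCN(C(=S)Nc1cccnc1)C2` is unmeasured. It differs from compound 1 by a group of 9 heavy atoms (6 carbon, 2 nitrogen, 1 sulfur; one six-membered aromatic ring with 1 hetero atom) in place of a group of 9 heavy atoms (7 carbon, 2 chlorine; one six-membered aromatic ring of carbon only), on an amine nitrogen in a ring. Here the benzyl group is removed altogether and a thiourea-linked pyridyl enters in its place. For the measured compounds named here, no measured step changes this part of the core in such a way; the step from compound 2 to compound 3 concerns only the pattern of chlorines on a retained benzyl and does not carry over. With nothing to lean on, no direction beyond the scatter is expected, and the estimate for compound 4 is simply set close to compound 1: 15000 nM, expected between 3000 nM and 50000 nM, a step of a 1.1-fold lower number from compound 1 to compound 4 (0.02 log units; within the scatter).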

Compound 4, half-maximal inhibitory concentration: 33900 nM
For compound 4 the middle estimate is 2.3-fold (0.35 log units) below the measured one; measured number inside the range.
By their numbers in this assay, from the lowest: compounds 3 and 1 (each within the scatter of the next); then compound 4. At a limit, above all of these: compound 2.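

In this assay, among the compounds shown here, a 2.1-fold higher number from compound 1 to compound 4 (0.33 log units; beyond the scatter), a modest step beyond the scatter, and this is the first reading at the amine nitrogen in a ring in which the benzyl group does not stay in place. The earlier step showed only that the pattern of chlorines matters on a retained benzyl, whereas this one shows that the whole 3,5-dichlorobenzyl can leave and a numerical value can still be read, at a modest cost in this series. The change replaces the carbon-only ring, the link to the nitrogen and the ring type in a single step, and nothing measured here accounts for the step or divides it among these parts.

Open, going by these compounds, is whether the higher number goes with the thiourea link or with the pyridyl: a phenyl on the same thiourea, or a urea carrying the same pyridyl, would separate the two. Also open, on these data alone, is how a methyl or a bare hydrogen on this nitrogen compares with compound 1, which would show how much any larger group here contributes.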